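Notes on replacing cyclohexyl with methoxy in compound 1

This account rests on a few compounds, and the source may have more. Where it says the series, first, only, none or still open, it means among the compounds named here.

Measured in a functional assay on MES-SA cells (Homo sapiens) for cytotoxicity, read by luminescence and CellTiter-Glo, with a stated time of 72 h; a lower number here means a stronger inhibitor, a higher number a weaker inhibitor
- compound 1 (`COC[C@H](NC(=O)c1cc(C)on1)C(=O)N[C@@H](CC1CCCCC1)C(=O)N[C@@H](CC(C)C)C(=O)[C@@]1(C)CO1`) gives 210 nM as its value
- compound 2 (`Cc1cc(C(=O)N[C@@H](CC(C)C)C(=O)N[C@@H](CCc2ccccc2)C(=O)N[C@@H](CC(C)C)C(=O)[C@@]2(C)CO2)n[nH]1`) gives 103 nM as its value

Compound 1 stands highest of these two numbers, and its nearest neighbour is compound 2, lower by a gap beyond the scatter. For the measured compounds named here, the two differ in more than one place, so no measured single-place step is available.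

Compound 3 (`COC[C@H](NC(=O)c1cc(C)on1)C(=O)N[C@@H](COC)C(=O)N[C@@H](CC(C)C)C(=O)[C@@]1(C)CO1`) is not yet measured. Compared with compound 1, it has methoxy in place of cyclohexyl on a saturated chain carbon, two bonds along the chain from an amide-type nitrogen and a carbonyl carbon. Going by the values given here, with no measured precedent for this change, a higher number in this assay is expected, meaning a weaker inhibitor, by a step beyond the scatter. The estimated move is a 3.3-fold higher number from compound 1 to compound 3 (0.52 log units; beyond the scatter) on this reading. Compound 3 is expected at 700 nM, with an estimated range of 200 nM to 2500 nM as the likely span.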

Compound 3, half-maximal inhibitory concentration: 22 nM
Compound 3: middle estimate off by 32-fold (1.50 log units), on the high side; the whole stated range lies above it.
By their numbers in this assay, from the lowest: compound 3; then compound 2; then compound 1.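

At this place, on a saturated chain carbon, two bonds along the chain from an amide-type nitrogen and a carbonyl carbon, the ring of the cyclohexyl group is not required for activity in this assay within this pair. Methoxy in place of cyclohexyl gives a 9.5-fold lower number from compound 1 to compound 3 (0.98 log units; beyond the scatter) with the rest of the core of compound 1 unchanged, so fewer heavy atoms and one added hydrogen-bond acceptor here go with a lower number. Nothing available accounts for this step.

A single pair cannot separate the loss of the ring from the entry of the oxygen, and a plain ethyl group, a hydroxyl or a longer ether chain at this place would be needed to do so. From the compounds shown here alone, whether the step carries over to the core of compound 2 also remains open.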